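Swapping the Aryl Group of Compound 1 for a Tert-Butylphenyl

The source may report more compounds than this note shows. Statements on the series, on what has been measured and on what is new or still open speak of the compounds shown alone.

Measured so far in a functional assay on CCRF-CEM cells (Homo sapiens) for antiproliferative activity, read by MTT assay, with a stated time of 72 h, tested at 100 uM; a higher number here means a weaker effect of the compound at the concentration tested, a lower number a stronger effect:
Compound 1 `COC(C(=O)OC(C)Cn1cnc2c1c(=O)n(C)c(=O)n2C)c1cccc2ccccc12` gives 51.4%.
Compound 2 `Cc1ccc(C(=O)CC(=O)OC(C)Cn2cnc3c2c(=O)n(C)c(=O)n3C)cc1` gives 67.3%.
Compound 3 `CC(Cn1cnc2c1c(=O)n(C)c(=O)n2C)OCc1cn(-c2cccc3ccccc23)nn1` gives 34.2%.

Compound 1 stands second highest among these three numbers. Its nearest neighbour is compound 2, whose number lies higher by a gap beyond the usual scatter; compound 3 lies furthest away, lower by a gap that is also beyond the scatter. Compound 4 `COC(C(=O)OC(C)Cn1cnc2c1c(=O)n(C)c(=O)n2C)c1ccc(C(C)(C)C)cc1` has not yet been measured. Among the measured compounds shown here, it differs from compound 1 in a single place: 4-(tert-butyl)phenyl in place of naphthalen-1-yl on a saturated chain carbon bound to a carbonyl carbon and an oxygen on a saturated carbon No measured pair shows the effect of such a change, so in this assay only a small step is expected, in no confident direction, quite possibly within the scatter. The value of compound 4 is estimated at 55%, within a range from 35% to 75%. This amounts to an expected step of a number 3.6 percentage points higher from compound 1 to compound 4 (within the scatter).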

Compound 4, a percentage reported as activity, at one concentration (the size of the read-out at that concentration, not a potency): 28.6%
Beside the measured number, compound 4's estimate is 26.4 percentage points above it; the measured number lies below the stated range.
By their numbers in this assay, from the lowest: compounds 4 and 3 (each within the scatter of the next); then compound 1; then compound 2.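

In this assay, the saturated chain carbon bound to a carbonyl carbon and an oxygen on a saturated carbon proves sensitive to its aryl group: 4-(tert-butyl)phenyl in place of naphthalen-1-yl gives a number 22.8 percentage points lower from compound 1 to compound 4 (beyond the scatter) and so a stronger effect. The number of heavy atoms stays the same, while the aromatic rings drop from two to one, so the second ring is not needed for this effect. Nothing measured here explains why the number moved. Still open, on these data alone, is whether the tert-butyl group itself matters, and whether an unsubstituted phenyl or a phenyl carrying a carboxylic acid would act alike.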